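Removing the nitro group from the most active thiadiazole

This account rests on a few compounds, and the source may have more. Where it says the series, first, only, none or still open, it means among the compounds named here.

Three compounds have been examined in a functional assay on the whole organism (strain albino) with Mus musculus as the target, in the maximal electroshock model, with a stated time of 0.5 h; on this read-out higher numbers stand for an effect only at larger amounts of compound and lower numbers for an effect already at smaller amounts. Compound 1 `Cc1ccc(Nc2nnc(Nc3nc(-c4ccc(Br)cc4)cs3)s2)cc1` gives 100 mg/kg, compound 2 `Cc1ccc(Nc2nnc(Nc3nc(-c4ccc([N+](=O)[O-])cc4)cs3)s2)cc1` gives 30 mg/kg, and compound 3 `O=[N+]([O-])c1ccc(-c2csc(Nc3nnc(Nc4ccccc4)s3)n2)cc1` gives 100 mg/kg. Compound 2 therefore stands lowest of the three numbers, both of its neighbours being beyond the scatter. Compound 4 `Cc1ccc(Nc2nnc(Nc3nc(-c4ccccc4)cs3)s2)cc1` differs from compound 2 by hydrogen in place of nitro on an aromatic carbon. The step of a 3.3-fold lower number from compound 1 to compound 2 (0.52 log units; beyond the scatter) shows that introducing nitro in place of bromo lowered the number, and the step of a 3.3-fold higher number from compound 2 to compound 3 (0.52 log units; beyond the scatter) shows that removing a group from the same core raised it. Both point the same way: taking nitro away is expected to raise the number in this assay by a modest amount, a 3.3-fold higher number from compound 2 to compound 4 (0.52 log units; beyond the scatter). Compound 4 is thus estimated at 100 mg/kg, with a range of 30 mg/kg to 300 mg/kg.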

Compound 4, minimum effective dose: 100 mg/kg
Estimate against measurement, compound 4: no gap at the digits printed, within the range that was stated.
By their numbers in this assay, from the lowest: compound 2; then compounds 1, 3 and 4 (each within the scatter of the next).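

In this assay, the change from 4-nitrophenyl to phenyl is now seen on its own (a 3.3-fold higher number from compound 2 to compound 4 (0.52 log units; beyond the scatter)), so the nitro group itself separates compound 2 from compound 4 on this core. Hydrogen in place of bromo gives a different picture (no change at the digits printed from compound 1 to compound 4 (within the scatter)): at this position, bromo and hydrogen cannot be told apart, and only nitro stands out among the three groups. Nothing measured here speaks to why nitro differs from the other two. On these data alone, whether an amine or a carboxylic acid at this position would read like nitro or like hydrogen stays open. So does whether the nitro-to-hydrogen step holds on the core of compound 3.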